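A few compounds are considered here, and "the series" means these few. Any claim that something is new, unique, unknown or untested is made for them only; others in the source may bear on it.

In an ADME assay on HEK293 cells (Homo sapiens) for cytotoxicity, read by MTT assay, with a stated time of 44 h (a higher number here means a weaker inhibitor, a lower number a stronger inhibitor), compound 2 `CCC1(c2cccc(Cl)c2)ON=C(c2cccc(Cl)c2)O1` gives only a limit, > 100000 nM. Compound 1 `CCC1(c2cccc(Cl)c2)ON=C(c2ccccc2Cl)O1` likewise gives only a limit in this assay, > 100000 nM. Compound 3 `Clc1cccc(C2=NOC(c3cccc(Cl)c3)O2)c1` also stands at a limit in this assay, > 100000 nM. All three values sit at the limit of > 100000 nM in this assay, at which 3 of the 3 values shown sit, so the step that the two limits leave unreadable from compound 1 to compound 2 and the step that the two limits leave unreadable from compound 2 to compound 3 cannot be read in size. Compound 4 `CCC1(c2cccc(Cl)c2)ON=C(c2ccc(Cl)cc2)O1` differs from compound 2 by 4-chlorophenyl in place of 3-chlorophenyl on a carbon with a double bond to nitrogen; in words, a 4-chlorophenyl in place of a 3-chlorophenyl on a carbon with a double bond to nitrogen. Neither measured step gives a readable size, so no step beyond the scatter is expected, and the step of a number no higher from compound 2 to compound 4 (the limit leaves the size open) is estimated as nil. Compound 4 is therefore expected to give 100000 nM, within 40000 nM to 300000 nM, most likely reported again as a limit.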

Compound 4, half-maximal inhibitory concentration: > 100000 nM
Compound 4: only a limit was reported; the forecaster's own chance of this, stated with the estimate: 85%; the middle value lies on the limit itself.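

The steps to compound 4 from compound 1 and compound 2 cannot be read in size, so no new step results: the limit of > 100000 nM in this assay, at which 4 of the 4 values shown sit.

The compounds shown leave open whether any change to the shared core would give a measurable value in this assay.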